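Methyl to 4-methylphenyl on the sulfonyl sulfur

This account rests on a few compounds, and the source may have more. Where it says the series, first, only, none or still open, it means among the compounds named here.

In a functional assay on HT-29 cells (Homo sapiens) for inhibition, read by CellTiter-Glo, with a stated time of 72 h (a lower number here means that less compound is tolerated, a higher number that more compound is tolerated), compound 1 (`CC1=C(CC(=O)N2CCN(c3ccncc3)CC2)c2cc(F)ccc2/C1=C\c1ccc([S+](C)[O-])cc1`) gives 9200 nM and compound 2 (`CC1=C(CC(=O)N(C)CCN(C)S(C)(=O)=O)c2cc(F)ccc2/C1=C\c1ccc([S+](C)[O-])cc1`) gives 12400 nM and so stands within the scatter of compound 1. Compound 3 (`CC1=C(CC(=O)N(C)CCN(C)S(=O)(=O)c2ccc(C)cc2)c2cc(F)ccc2/C1=C\c1ccc([S+](C)[O-])cc1`) carries 4-methylphenyl in place of methyl on a sulfonyl sulfur. Among the compounds with values here, the only measured step (a 1.3-fold higher number from compound 1 to compound 2 (0.13 log units; within the scatter)) changes the group on a carbonyl carbon, and no measured step changes the group on the sulfonyl sulfur. That thin evidence supports no expected change beyond the scatter in this assay (estimated: a 1.4-fold lower number from compound 2 to compound 3 (0.14 log units; within the scatter)). The estimated value for compound 3 is 9000 nM (range 4000 nM to 18000 nM).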

Compound 3, half-maximal cytotoxic concentration: 6180 nM
Compound 3: the middle estimate sits 1.5-fold (0.16 log units) above what was measured; the range from low to high includes it.
By their numbers in this assay, from the lowest: compounds 3, 1 and 2 (each within the scatter of the next).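

On the sulfonyl sulfur, 4-methylphenyl in place of methyl gives a 2.0-fold lower number from compound 2 to compound 3 (0.30 log units; within the scatter) in this assay, the only step shown at this position. A six-membered aromatic ring of carbon only is therefore accommodated there, with the number staying within the scatter. No measurement at hand accounts for the size of this step. From the compounds shown here alone, it remains open how a phenyl group carrying an amine or a carboxylic acid would read on the sulfonyl sulfur. Going by these compounds, a longer alkyl chain such as butyl at the same place also remains open.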